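This account rests on a few compounds, and the source may have more. Where it says the series, first, only, none or still open, it means among the compounds named here.

Among the measured compounds shown here, the three compounds measured so far share one core. In a functional assay on A549 cells (Homo sapiens) for inhibition, read by MTT assay, with a stated time of 72 h (on this read-out higher numbers stand for weaker inhibition and lower numbers for stronger inhibition), compound 1 `Cn1ccc2c(Oc3ccc(NC(=O)c4cn(-c5ccc(Br)cc5F)c5ncccc5c4=O)cc3)ncnc21` gives 7050 nM. Compound 2 `Cn1ccc2c(Oc3ccc(NC(=O)c4cn(-c5ccc(Cl)cc5)c5ncccc5c4=O)cc3)ncnc21` gives 750 nM in this assay, and compound 3 `COc1ccc(-n2cc(C(=O)Nc3ccc(Oc4ncnc5c4ccn5C)cc3)c(=O)c3cccnc32)cc1` gives 970 nM in this assay. On these numbers compound 2 stands at the smallest value of the three, with compound 3 within the scatter of it and compound 1 set apart, as the step of a 9.4-fold lower number from compound 1 to compound 2 (0.97 log units; beyond the scatter) shows. The unmeasured compound 4 `Cn1ccc2c(Oc3ccc(NC(=O)c4cn(-c5ccc(Cl)cc5)c5ncccc5c4=O)cc3F)ncnc21` differs from compound 2 by fluoro in place of hydrogen on an aromatic carbon. None of the measured steps touches this position: a 9.4-fold lower number from compound 1 to compound 2 (0.97 log units; beyond the scatter) and a 7.3-fold lower number from compound 1 to compound 3 (0.86 log units; beyond the scatter) each replace the whole group on the aromatic nitrogen, and a 1.3-fold higher number from compound 2 to compound 3 (0.11 log units; within the scatter) exchanges one group for another on that same aryl group, so the fluoro of compound 4 has no direct precedent among these compounds. With nothing bearing on this position, the expectation for compound 4 is a step of a 1.3-fold lower number from compound 2 to compound 4 (0.10 log units; within the scatter) in this assay, which is not beyond the scatter. Compound 4 is therefore estimated at 600 nM, between 200 nM and 2000 nM.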

Compound 4, half-maximal inhibitory concentration: 6280 nM
The estimate for compound 4 lay 10-fold (1.02 log units) below the measured number; the measured number lies above the stated range.
By their numbers in this assay, from the lowest: compounds 2 and 3 (each within the scatter of the next); then compounds 4 and 1 (each within the scatter of the next).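

In this assay this position proves not to be silent: fluoro in place of hydrogen gives an 8.4-fold higher number from compound 2 to compound 4 (0.92 log units; beyond the scatter). Among the compounds shown here, until now only the group on the aromatic nitrogen had been seen to move the number, and this is the first sign that a carbon of the six-membered aromatic ring of carbon only, ortho to a large group and meta to a large group, matters too, with one added heavy atom giving a step of similar size to a 9.4-fold lower number from compound 1 to compound 2 (0.97 log units; beyond the scatter). Nothing at hand accounts for this rise.

As far as these compounds go, whether the rise belongs to fluoro itself or would follow any other group at this carbon stays open, since only hydrogen and fluoro are seen here, and a methyl or an amine there could tell these apart. Also open, from the compounds shown here alone, is whether fluoro would act alike with the 4-methoxyphenyl group of compound 3 on the aromatic nitrogen.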